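The compounds below may be only part of what the source reports. "The series", "measured", "known", "first", "only" and "open" are said of these compounds alone.

In a functional assay on CCRF-CEM cells (Homo sapiens) for antiproliferative activity, with a stated time of 72 h (on this read-out higher numbers stand for weaker inhibition and lower numbers for stronger inhibition), compound 1 (`OC[C@H]1O[C@@H](n2cnc3c(NCc4cccc(F)c4)ncnc32)[C@H](O)[C@@H]1O`) gives 4000 nM, compound 2 (`OC[C@H]1O[C@@H](n2cnc3c(NCc4ccccc4Cl)ncnc32)[C@H](O)[C@@H]1O`) gives 14500 nM and compound 3 (`OC[C@H]1O[C@@H](n2cnc3c(NCc4ccc(Br)cc4)ncnc32)[C@H](O)[C@@H]1O`) gives 20600 nM. Compound 3 stands at the high end of these numbers, but not alone. The gap to its nearest neighbour is a 1.4-fold higher number from compound 2 to compound 3 (0.15 log units; within the scatter), and the gap to its furthest is a 5.2-fold higher number from compound 1 to compound 3 (0.71 log units; beyond the scatter).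

The next change leads to compound 4 (`COc1ccccc1CNc1ncnc2c1ncn2[C@@H]1O[C@H](CO)[C@@H](O)[C@H]1O`), with 2-methoxyphenyl in place of 4-bromophenyl on a saturated chain carbon bound to a nitrogen on an aromatic ring.

Among the measured compounds shown here, no measured compound carries a methoxy group, so the steps bear on this change only indirectly. Exchanging 2-chlorophenyl for 4-bromophenyl gave a 1.4-fold higher number from compound 2 to compound 3 (0.15 log units; within the scatter). The larger steps both involve compound 1, namely a 3.6-fold higher number from compound 1 to compound 2 (0.56 log units; beyond the scatter) and a 5.2-fold higher number from compound 1 to compound 3 (0.71 log units; beyond the scatter), and compound 1 carries 3-fluorophenyl, which compound 4 does not. The closest reference is compound 2, at 14500 nM, whose 2-chlorophenyl group has the same numbered position as the 2-methoxyphenyl group.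

The step expected in this assay is therefore none beyond the scatter: a 1.7-fold lower number from compound 3 to compound 4 (0.23 log units; within the scatter). The estimated value for compound 4 is 12000 nM, with an expected range of 4000 nM to 30000 nM.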

Compound 4, half-maximal inhibitory concentration: 3200 nM
Compound 4: middle estimate off by 3.8-fold (0.57 log units), on the high side, outside the stated range (below it).
By their numbers in this assay, from the lowest: compounds 4 and 1 (each within the scatter of the next); then compounds 2 and 3 (each within the scatter of the next).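

In this assay, the benzyl group on the nitrogen responds to more than a change of halogen: 2-methoxyphenyl in place of 4-bromophenyl gives (a 6.4-fold lower number from compound 3 to compound 4 (0.81 log units; beyond the scatter)), and methoxy in place of chloro on an aromatic carbon gives (a 4.5-fold lower number from compound 2 to compound 4 (0.66 log units; beyond the scatter)), so the two groups named at the 2-position, 2-chlorophenyl and 2-methoxyphenyl, do not behave alike. Compound 1 no longer stands alone at the low end of the series, as its 3-fluorophenyl group and the 2-methoxyphenyl group of compound 4 cannot be told apart here (a 1.3-fold lower number from compound 1 to compound 4 (0.10 log units; within the scatter)), which shows that more than one substitution place on this ring is compatible with the lower numbers. Nothing measured on these compounds accounts for the difference between methoxy and chloro, so the step stands as an observation only.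

The compounds shown leave open whether the lower number follows methoxy at any place on the ring, as 3-methoxyphenyl and 4-methoxyphenyl would test. They also leave open whether it extends to a 2-ethoxyphenyl or a 2-hydroxyphenyl group in the same place.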